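Swapping an anilino group for dipropylamino on a shared core

A few compounds are considered here, and "the series" means these few. Any claim that something is new, unique, unknown or untested is made for them only; others in the source may bear on it.

Measured compounds:
compound 1 `Cc1ccc(NC2=CC(=O)c3nc4n(c3C2=O)[C@H]2OC[C@@H](O)[C@H]2OC4)cc1`: 3860 nM
compound 2 `Cc1ccc(NC2=CC(=O)c3c(nc4n3[C@H]3OC[C@@H](O)[C@H]3OC4)C2=O)cc1C`: 4320 nM
compound 3 `O=C1C=C(Nc2ccc(Br)cc2)C(=O)c2c1nc1n2[C@H]2OC[C@@H](O)[C@H]2OC1`: 3830 nM

All three were tested in a functional assay on HeLa cells (Homo sapiens) for inhibition, read by sulforhodamine B assay (on this read-out lower numbers stand for stronger inhibition and higher numbers for weaker inhibition), and compound 1, compound 2 and compound 3 give numbers that lie within the usual scatter of one another. Compound 2 sits at one end of the three, but compound 1 is its nearest neighbour and compound 3 its furthest, and neither gap is beyond the scatter, so the three cannot be told apart on these data.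

Compound 4 `CCCN(CCC)C1=CC(=O)c2c(nc3n2[C@H]2OC[C@@H](O)[C@H]2OC3)C1=O` differs from compound 2 in one place: dipropylamino in place of (3,4-dimethylphenyl)amino on a double-bonded ring carbon. Going by the values given here, the only step among the measured compounds, a 1.0-fold lower number from compound 1 to compound 3 (0.00 log units; within the scatter), alters a substituent on the aromatic ring that compound 4 no longer carries, and that step was within the scatter. Among the compounds with values here, no measured step therefore speaks to the exchange of an aryl amine for a dialkyl amine, and the direction of the change cannot be read from these compounds.

Compound 4 is expected to give about 6000 nM in this assay, with a wide range from 1500 nM to 25000 nM. This estimate means a step of a 1.4-fold higher number from compound 2 to compound 4 (0.14 log units; within the scatter), expected to be small and uncertain in direction.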

Compound 4, half-maximal inhibitory concentration: > 16000 nM
Compound 4 ended at the assay's limit; the forecaster's own chance of this, stated with the estimate: 12%; middle value at least 2.6-fold (0.42 log units) away from the limit.
By their numbers in this assay, from the lowest: compounds 3, 1 and 2 (each within the scatter of the next). At a limit, above all of these: compound 4.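

In this assay, replacing (3,4-dimethylphenyl)amino with dipropylamino on the double-bonded ring carbon gives an at least 3.7-fold higher number from compound 2 to compound 4 (0.56 log units; beyond the scatter), so the group at this position can move the number beyond the scatter. Going by these compounds alone, the earlier compounds could not show this, since their only step, a 1.0-fold lower number from compound 1 to compound 3 (0.00 log units; within the scatter), changed a substituent on the aromatic ring and stayed within the scatter. The result for compound 4 is a limit of the assay and not a number, so the step gives only a minimum and its full size stays unknown: the limit of > 16000 nM in this assay, at which 1 of the 4 values shown sits.

The exchange removes the aromatic ring and the hydrogen-bond donor together, so these compounds cannot say which of the two losses goes with the weaker result; propylamino, which keeps the amine hydrogen without the ring, and N-methylanilino, which keeps the ring without that hydrogen, would pull the two apart. Going by these compounds, it also remains open whether dipropylamino is a special case or whether other dialkyl amines, such as dimethylamino, or cyclic amines, such as morpholino or piperidino, behave in the same way at this position.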